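Piperazine sulfonamide series: benzyl to phenylethyl switch

The source may hold more compounds than are shown below. What is called first, only, known or untested is meant among the compounds shown, and "the series" means these compounds.

Compound 1 `CCCn1c(=O)[nH]c2nc(-c3ccc(S(=O)(=O)N4CCN(Cc5cccc(C)c5)CC4)cc3)[nH]c2c1=O` sits at the floor of an assay on CHO cells for displacement of a labelled ligand from adenosine receptor A3 (Homo sapiens), read by scintillation counting, with a stated time of 45 min, in the presence of a further agent that is not named here (a higher number here means a weaker inhibitor, a lower number a stronger inhibitor), where compound 1 gives > 1000 nM, a limit rather than a number. Compound 2 `CCCn1c(=O)[nH]c2nc(-c3ccc(S(=O)(=O)N4CCN(c5ccccc5F)CC4)cc3)[nH]c2c1=O` likewise gives > 1000 nM in this assay, also a limit. The step that the two limits leave unreadable from compound 1 to compound 2 therefore cannot be read, and the limit of > 1000 nM in this assay, at which 2 of the 2 values shown sit, is all the evidence on this series. Compound 3 `CCCn1c(=O)[nH]c2nc(-c3ccc(S(=O)(=O)N4CCN(C(C)c5ccccc5)CC4)cc3)[nH]c2c1=O` differs from compound 1 by 1-phenylethyl in place of 3-methylbenzyl on an amine nitrogen in a ring. For the measured compounds named here, no measured step bears on this change, and both values shown are limits, so no direction can be inferred. Compound 3 is expected to give 3000 nM in this assay, within 1000 nM to 20000 nM, most likely again as a limit. The expected step that the limit leaves unreadable from compound 1 to compound 3 is accordingly small.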

Compound 3, inhibition constant: > 1000 nM
Compound 3: a limit, no number; the forecaster's own chance of this, stated with the estimate: 80%; the middle value lies beyond the limit too.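

Compound 3 gives > 1000 nM, a limit and not a number. The steps to compound 3 from compound 1 and compound 2 therefore cannot be read: the limit of > 1000 nM in this assay, at which 3 of the 3 values shown sit.

On these data alone, how compound 1, compound 2 and compound 3 rank, and whether any group on this amine nitrogen in a ring gives a readable inhibition constant, stays open.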